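Trading a Chlorine for a Trifluoromethyl Group

A few compounds are considered here, and "the series" means these few. Any claim that something is new, unique, unknown or untested is made for them only; others in the source may bear on it.

Going by the values given here, compound 3 `COc1cc(NC(C)CCCNC(=O)NNC(=O)Nc2cccc(Cl)c2)c2ncccc2c1` is tested in a functional assay on MIA PaCa-2 cells (Homo sapiens) for inhibition, read by MTT assay, with a stated time of 72 h (on this read-out higher numbers stand for weaker inhibition and lower numbers for stronger inhibition), where it gives 74000 nM, the highest of the three numbers measured so far. Compound 1 `COc1cc(NC(C)CCCNC(=O)NNC(=O)Nc2cccc(F)c2)c2ncccc2c1` gives 69000 nM, and compound 2 `COc1cc(NC(C)CCCNC(=O)NNC(=O)Nc2cccc(C(F)(F)F)c2)c2ncccc2c1` gives 5600 nM. The new compound 4 `COc1cc(NC(C)CCCNC(=O)NNC(=O)Nc2ccc(C(F)(F)F)cc2)c2ncccc2c1` differs from compound 3 by 4-(trifluoromethyl)phenyl in place of 3-chlorophenyl on an amide-type nitrogen. Among the compounds with values here, two measured steps bear on this: the exchange a 13-fold higher number from compound 2 to compound 3 (1.12 log units; beyond the scatter) and the exchange a 12-fold lower number from compound 1 to compound 2 (1.09 log units; beyond the scatter) both show that a trifluoromethyl group goes with a markedly lower number than chloro or fluoro. Within the data shown here, compound 4 carries that group in a 4-(trifluoromethyl)phenyl arrangement, which no measured compound covers, so the expectation is tempered. The estimated step is an 8.2-fold lower number from compound 3 to compound 4 (0.91 log units; beyond the scatter). Compound 4 is expected to give about 9000 nM, within 2500 nM to 40000 nM.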

Compound 4, half-maximal inhibitory concentration: 19000 nM
Compound 4: middle estimate off by 2.1-fold (0.32 log units), on the low side, within the range that was stated.
By their numbers in this assay, from the lowest: compound 2; then compound 4; then compounds 1 and 3 (each within the scatter of the next).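

Exchanging 3-(trifluoromethyl)phenyl for 4-(trifluoromethyl)phenyl on the amide-type nitrogen gives a 3.4-fold higher number from compound 2 to compound 4 (0.53 log units; beyond the scatter) in this assay and shows that the same group can behave differently depending on where it is attached. The 4-(trifluoromethyl)phenyl group still retains an advantage over both halogen-bearing rings, with a 3.9-fold lower number from compound 3 to compound 4 (0.59 log units; beyond the scatter) and a 3.6-fold lower number from compound 1 to compound 4 (0.56 log units; beyond the scatter) as the two modest steps. No available evidence accounts for these differences.

As far as these compounds go, whether 4-chlorophenyl would follow the same trend remains open. So does whether a nitrile or a carboxylic acid could replace trifluoromethyl and keep the lower number.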